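An amino group on the phenoxy ring of compound 2

The compounds below may be only part of what the source reports. "The series", "measured", "known", "first", "only" and "open" are said of these compounds alone.

- compound 1 `COc1ccc(Oc2ccccc2NC(C)=C2C(=O)CC(c3ccccc3)CC2=O)cc1`: 160 nM
- compound 2 `CC(Nc1ccccc1Oc1ccccc1)=C1C(=O)CC(c2ccccc2)CC1=O`: 79 nM
- compound 3 `CC(Nc1ccccc1Oc1cccc(N)c1)=C1C(=O)CC(c2ccccc2)CC1=O`: not yet measured

In a functional assay on HeLa cells (Homo sapiens) for antiproliferative activity, read by cell counting, with a stated time of 3 days (on this read-out lower numbers stand for stronger inhibition and higher numbers for weaker inhibition), compound 2 gives 79 nM, the lower of the two measured numbers. Compound 3 has amino in place of hydrogen on an aromatic carbon, meta to a large group: amino in place of hydrogen on an aromatic carbon. For the measured compounds named here, one measured step bears on this change, a modest one beyond the scatter: a 2.0-fold lower number from compound 1 to compound 2 (0.31 log units; beyond the scatter). There, the compound with hydrogen gave the lower number, so a similarly modest rise is expected, though this single step shows no pattern. The expected step is a 1.5-fold higher number from compound 2 to compound 3 (0.18 log units; within the scatter). Compound 3 is estimated at 120 nM, with an expected range from 45 nM to 320 nM.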

Compound 3, half-maximal inhibitory concentration: 82 nM
Compound 3: middle estimate off by 1.5-fold (0.17 log units), on the high side, within the range that was stated.
By their numbers in this assay, from the lowest: compounds 2, 3 and 1 (each within the scatter of the next, the first and the last beyond it).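

In this assay, amino on this aromatic carbon, meta to a large group, is tolerated, with a 1.0-fold higher number from compound 2 to compound 3 (0.02 log units; within the scatter). Replacing 4-methoxyphenyl with 3-aminophenyl also stays within the scatter, with a 2.0-fold lower number from compound 1 to compound 3 (0.29 log units; within the scatter), whereas the earlier removal of methoxy from compound 1 to give compound 2 lay just beyond it. Nothing available explains either step. On these data alone, whether a hydroxyl, a carboxylic acid or an acetamide would also be tolerated at this position remains open, and so does how far a larger amine could go.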